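Trimming Benzyloxy to Ethoxy: Expected Cytotoxicity of Compound 3

A few compounds are considered here, and "the series" means these few. Any claim that something is new, unique, unknown or untested is made for them only; others in the source may bear on it.

Two compounds built on the same isopropyl-amide core were assessed in an ADME assay on HEK293 cells (Homo sapiens) for cytotoxicity, read by CellTiter-Glo and resazurin assay, with a stated time of 72 h; a higher number here means that more compound is needed for the effect, a lower number that less compound is needed. Compound 1 `CC(C)N(Cc1cccc(OCCCCCC(=O)O)c1)C(=O)c1ccc(-c2ccoc2)cc1` gives > 26000 nM in this assay, which is a limit of the assay and not a number. Compound 2 `CC(C)N(Cc1cccc(OCCCCCC(=O)O)c1)C(=O)c1ccc(-c2cccc(OCc3ccccc3)c2)cc1` gives > 26000 nM in this assay, again a limit rather than a measured number. Both values therefore sit at the same ceiling, as the limit of > 26000 nM in this assay, at which 2 of the 2 values shown sit, records, so compound 2 cannot be ranked against compound 1 on these numbers; it shares the limit.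

Compound 3 `CCOc1cccc(-c2ccc(C(=O)N(Cc3cccc(OCCCCCC(=O)O)c3)C(C)C)cc2)c1` has not yet been measured in this assay. It differs from compound 2 by methyl in place of phenyl on a saturated chain carbon bound to an oxygen on an aromatic ring, benzyloxy becoming ethoxy. For the measured compounds named here, no step between measured compounds exists to gauge this change, and no step beyond the scatter is expected; the step from compound 2 to compound 3 is estimated at a step that the limit leaves unreadable from compound 2 to compound 3. Compound 3 is expected to give about 30000 nM, within 15000 nM to 80000 nM, most likely reported once more only as a limit.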

Compound 3, half-maximal effective concentration: > 20800 nM
Compound 3 gave a limit, no number; the forecaster's own chance of this, stated with the estimate: 85%; the middle value lies beyond the limit too.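

In this assay compound 3 gives > 20800 nM, which is a limit and not a number. For the compounds shown here, compound 1 and compound 2 also stand at limits, so no step from either of them to compound 3 can be read. The compounds shown leave open whether swapping benzyloxy for ethoxy, or furan-3-yl for 3-ethoxyphenyl, changes cytotoxicity at all.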